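Ester for Hydroxamic Acid in a Sulfonamide Series

The source may hold more compounds than are shown below. What is called first, only, known or untested is meant among the compounds shown, and "the series" means these compounds.

In a functional assay on HL-60 cells (Homo sapiens) for antiproliferative activity, tested at 100 uM (on this read-out lower numbers stand for a weaker effect and higher numbers for a stronger effect at the one concentration tested), compound 2 `Cc1cc2cc(NS(=O)(=O)Cc3ccc(C(=O)NO)cc3)ccc2n(C)c1=O` gives 27%. Going by the values given here, compound 1 `COC(=O)c1ccc(CS(=O)(=O)Nc2ccc3c(c2)cc(C)c(=O)n3C)cc1`, in this assay, gives 78%, so that the single change methoxy in place of hydroxyamino on a carbonyl carbon made a step of a number 51 percentage points higher from compound 2 to compound 1 (beyond the scatter). Compound 3 `COc1ccc(C(=O)NO)cc1S(=O)(=O)Nc1ccc2c(c1)cc(C)c(=O)n2C` gives 39% in this assay; how its core differs from that of compound 2 is not broken down here. Compound 4 `COC(=O)c1ccc(OC)c(S(=O)(=O)Nc2ccc3c(c2)cc(C)c(=O)n3C)c1` carries the same change relative to compound 3, namely (methoxy in place of hydroxyamino on a carbonyl carbon), at a place described in the same words as before.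

For compound 4 a step of a number 41 percentage points higher from compound 3 to compound 4 (beyond the scatter) is expected, resting on the step seen from compound 2 to compound 1, a number 51 percentage points higher from compound 2 to compound 1 (beyond the scatter), with the rise held back by the ceiling of the read-out. Compound 4 is therefore estimated at 80%, within a range of 55% to 98%.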

Compound 4, a percentage reported as inhibition, at one concentration (the size of the read-out at that concentration, not a potency): 66%
For compound 4 the middle estimate is 14 percentage points above the measured one, and the stated range covers the measured number.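

In this assay, putting methoxy in place of hydroxyamino on a carbonyl carbon again gave a rise, with a number 27 percentage points higher from compound 3 to compound 4 (beyond the scatter). The direction of the step therefore held on both cores, but its size did not carry over unchanged: the same change on two cores in this assay, a number 51 percentage points higher (beyond the scatter) from compound 2 to compound 1 and a number 27 percentage points higher (beyond the scatter) from compound 3 to compound 4, 24 percentage points apart, beyond the scatter of two such steps

These two pairs show that the direction can be carried from one core to the other, but they do not explain the difference in size or show how the change would behave on any further core. Going by these compounds, it remains open whether a carboxylic acid, an ethyl ester or a primary amide on the same carbonyl carbon would give a similar rise on either core. On these data alone, how each pair would compare at other concentrations is also open.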